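Carbamate for ethyl on the piperazine nitrogen

A few compounds are considered here, and "the series" means these few. Any claim that something is new, unique, unknown or untested is made for them only; others in the source may bear on it.

Two esters of the shared bicyclic alcohol carry measured numbers. Compound 1 `CCCCN(CCCC)CCC(=O)O[C@@H]1C[C@@H]2CC[C@@]1(C)C2(C)C` bears a dibutylamino-substituted propanoate; in an ADME assay on MDCK cells (Canis lupus familiaris) for cytotoxicity, read by MTT assay, with a stated time of 48 h (on this read-out lower numbers stand for higher toxicity in this test and higher numbers for lower toxicity in this test), compound 1 gives 41800 nM. Compound 2 `CCN1CCN(CC(=O)O[C@@H]2C[C@@H]3CC[C@@]2(C)C3(C)C)CC1` bears an acetate on an ethyl-substituted piperazine; in this assay compound 2 gives 100000 nM. Compound 2 therefore stands at the higher of the two numbers, and its gap to compound 1 lies beyond the usual scatter. Going by the values given here, no single-point step between measured compounds is available, so the effect of the change that leads to compound 3 `CCOC(=O)N1CCN(CC(=O)O[C@@H]2C[C@@H]3CC[C@@]2(C)C3(C)C)CC1` cannot be read from a precedent: ethoxycarbonyl in place of ethyl on an amine nitrogen in a ring. Among the compounds with values here, with no comparable pair to lean on, the step of no change at the digits printed from compound 2 to compound 3 (within the scatter) is expected to stay within the scatter, in no firm direction. In this assay compound 3 is accordingly estimated at 100000 nM, with a range from 40000 nM to 200000 nM.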

Compound 3, half-maximal cytotoxic concentration: > 852000 nM
Compound 3: no number, only a limit; the forecaster's own chance of this, stated with the estimate: 30%; middle value at least 8.5-fold (0.93 log units) from the limit.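

This position, an amine nitrogen in a ring, proves responsive in this assay: ethoxycarbonyl in place of ethyl gives an at least 8.5-fold higher number from compound 2 to compound 3 (0.93 log units; beyond the scatter), a shift toward lower toxicity in this test. It is the only single-place step shown, whereas compound 1 and compound 2 differ in more than one place and could not isolate any one change. Compound 3 carries a limit and not a number, so the step is bounded on one side only: the limit of > 852000 nM in this assay, at which 1 of the 3 values shown sits.

Open, going by these compounds, is whether an acetyl group, a methyl carbamate or a free amine on the same nitrogen would read closer to compound 2 or to compound 3. Also open, on these data alone, is whether ethoxycarbonyl would produce a similar step with a longer chain in the ester, such as the propanoate of compound 1.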